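Swapping 2-methylbutyl for isopentyl: a small step expected

The source may hold more compounds than are shown below. What is called first, only, known or untested is meant among the compounds shown, and "the series" means these compounds.

Compound 1 `C[C@H]1O[C@@H](n2cc(F)c(NC(=O)Oc3ccc(Cl)cc3)nc2=O)[C@H](O)[C@@H]1O` – 90 ug/mL
Compound 2 `C[C@H]1O[C@@H](n2cc(F)c(NC(=O)Oc3ccc([N+](=O)[O-])cc3)nc2=O)[C@H](O)[C@@H]1O` – 100 ug/mL
Compound 3 `CCC(C)COC(=O)Nc1nc(=O)n([C@@H]2O[C@H](C)[C@@H](O)[C@H]2O)cc1F` – 370 ug/mL

In a functional assay on NCI-H69 cells (Homo sapiens) for cytotoxicity, read by MTT assay, with a stated time of 3 days (on this read-out lower numbers stand for stronger inhibition and higher numbers for weaker inhibition), compound 3 has the highest number of the three at 370 ug/mL and so shows the weakest inhibition of the set. Compound 4 `CC(C)CCOC(=O)Nc1nc(=O)n([C@@H]2O[C@H](C)[C@@H](O)[C@H]2O)cc1F` has the same atoms as compound 3 but joined differently: isobutyl in place of sec-butyl on a saturated chain carbon bound to an oxygen next to a carbonyl group. Seen one bond further out, 2-methylbutyl becomes isopentyl.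

Within the data shown here, no measured pair makes this exact change, so the evidence is indirect. Replacing the 4-chlorophenyl group gave a 4.1-fold higher number from compound 1 to compound 3 (0.61 log units; beyond the scatter) and replacing the 4-nitrophenyl group gave a 3.7-fold higher number from compound 2 to compound 3 (0.57 log units; beyond the scatter) in the same test. Nitro in place of chloro gave a 1.1-fold higher number from compound 1 to compound 2 (0.05 log units; within the scatter) as well. Those two modest steps to compound 3 came from exchanging a whole aromatic group for a chain, whereas compound 4 only rearranges the chain. A step beyond the scatter is therefore not expected, and no direction is favoured. The expected change is a 1.1-fold lower number from compound 3 to compound 4 (0.02 log units; within the scatter) and it is estimated to be close to nil. For compound 4 the expected value is 350 ug/mL with an estimated range from 180 ug/mL to 650 ug/mL on this reasoning.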

Compound 4, half-maximal inhibitory concentration: 370 ug/mL
Compound 4: the middle estimate sits 1.1-fold (0.02 log units) below what was measured; low and high end bracket the measured number.
By their numbers in this assay, from the lowest: compounds 1 and 2 (each within the scatter of the next); then compounds 3 and 4 (each within the scatter of the next).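

In this assay, among these compounds, isobutyl in place of sec-butyl gives no change at the digits printed from compound 3 to compound 4 (within the scatter) and so rejoining the same chain atoms in this way leaves the read-out unchanged, which is the first direct look at how this chain's shape matters here. Compound 4 also stands apart from the aromatic compounds, with a 3.7-fold higher number from compound 2 to compound 4 (0.57 log units; beyond the scatter) and a 4.1-fold higher number from compound 1 to compound 4 (0.61 log units; beyond the scatter) in the direction of weaker inhibition, so a second chain now repeats the modest gap first seen with compound 3, and none of the four compounds goes against this pattern. No measurement of any property of these groups is available to account for either finding.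

Only two branched chains of one size are shown, so a straight butyl chain, a longer chain such as octyl, or a cyclohexyl ring on an oxygen next to a carbonyl group could still shift the number. As far as these compounds go, it also remains open whether a chain ending in an amine or a carboxylic acid, or a plain phenyl or benzyl group, would fall with the chains or with the substituted aromatic groups.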